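This account rests on a few compounds, and the source may have more. Where it says the series, first, only, none or still open, it means among the compounds named here.

Measured compounds:
- compound 1, `O=C([C@@H]1CCCN(S(=O)(=O)c2ccc(S(=O)(=O)C3CCC3)cc2)C1)N1CCC(F)(F)CC1`: 9 nM
- compound 2, `CCN(CC)C(=O)c1ccc(S(=O)(=O)N2CCC[C@@H](C(=O)N3CCC(F)(F)CC3)C2)cc1`: 70 nM
- compound 3, `CCN(CC)S(=O)(=O)c1ccc(S(=O)(=O)N2CCC[C@@H](C(=O)N3CCC(F)(F)CC3)C2)cc1`: 16 nM

In a functional assay on MIA PaCa-2 cells (Homo sapiens) for inhibition, read by MTT assay, with a stated time of 7 days (on this read-out lower numbers stand for stronger inhibition and higher numbers for weaker inhibition), compound 3 gives 16 nM, the second highest of the three numbers; its nearest neighbour is compound 1 at 9 nM, a gap within the scatter, while compound 2 lies furthest away, as a 4.4-fold lower number from compound 2 to compound 3 (0.64 log units; beyond the scatter) shows. Compound 4 is `CC(C)CS(=O)(=O)c1ccc(S(=O)(=O)N2CCC[C@@H](C(=O)N3CCC(F)(F)CC3)C2)cc1`, which differs from compound 3 by isobutyl in place of diethylamino on a sulfonyl sulfur. The step that bears most directly on this change is a 1.8-fold higher number from compound 1 to compound 3 (0.25 log units; within the scatter), since compound 1 also carries an alkyl group on that sulfonyl sulfur and the exchange for diethylamino stayed within the scatter. The other two steps, a 7.8-fold higher number from compound 1 to compound 2 (0.89 log units; beyond the scatter) and a 4.4-fold lower number from compound 2 to compound 3 (0.64 log units; beyond the scatter), swap a sulfonyl for a carbamoyl, which compound 4 does not do, so they bear only indirectly. Compound 4 is therefore expected to give a number close to compound 3, with a 1.3-fold lower number from compound 3 to compound 4 (0.12 log units; within the scatter) not beyond the scatter. The estimate for compound 4 in this assay is 12 nM, within 5 nM to 30 nM.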

Compound 4, half-maximal inhibitory concentration: 80 nM
The estimate for compound 4 lay 6.7-fold (0.82 log units) below the measured number, and the stated range ends below it.
By their numbers in this assay, from the lowest: compounds 1 and 3 (each within the scatter of the next); then compounds 2 and 4 (each within the scatter of the next).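

In this assay, the group on the sulfonyl sulfur proves decisive: a 5.0-fold higher number from compound 3 to compound 4 (0.70 log units; beyond the scatter), so the earlier closeness of cyclobutyl and diethylamino at this place does not carry over to isobutyl. An alkyl group there does not fix the number by itself either, as an 8.9-fold higher number from compound 1 to compound 4 (0.95 log units; beyond the scatter) separates two groups that both lack nitrogen. With isobutyl, the sulfonyl compound instead falls level with the diethylcarbamoyl compound, at a 1.1-fold higher number from compound 2 to compound 4 (0.06 log units; within the scatter).

Nothing available accounts for these differences. The compounds shown also leave open how a cyclopentyl group, a straight butyl chain or a piperidine on that sulfonyl sulfur would read, and so whether the cyclobutyl ring matters more than the size of the group.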